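A few compounds are considered here, and "the series" means these few. Any claim that something is new, unique, unknown or untested is made for them only; others in the source may bear on it.

Of the compounds shown here, three have been read in a functional assay on L5178Y cells (Mus musculus) for inhibition, read by MTT assay, with a stated time of 24 h (on this read-out lower numbers stand for stronger inhibition and higher numbers for weaker inhibition), so far. Compound 1 `Oc1ccc([C@@H]2C/C(=N\Nc3cnccn3)c3c(O)cc(O)cc3O2)cc1` gives >= 11300 nM as a limit of the assay and not a number. Compound 2 `COc1cc(O)c2c(c1)O[C@H](c1ccc(O)cc1)C/C2=N\NC(=O)c1cccs1` gives 9400 nM as a measured number. Compound 3 `CCN(CC)CC(O)COc1ccc([C@@H]2CC(=O)c3c(O)cc(OC)cc3O2)cc1` gives >= 11300 nM which is again only a limit. Compound 3 therefore stands at the limit of >= 11300 nM in this assay, at which 2 of the 3 values shown sit, and has no exact value to start from.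

Compound 4 `COc1cc(O)c2c(c1)O[C@H](c1ccc(OCC(O)Cc3c[nH]c4ccccc34)cc1)CC2=O` keeps the rest of compound 3 and changes in one place: 1H-indol-3-yl in place of diethylamino on a saturated chain carbon, two bonds along the chain from an oxygen on a saturated carbon with 1H-indol-3-yl in place of diethylamino on a saturated chain carbon, two bonds along the chain from an oxygen on a saturated carbon. For the measured compounds named here, no pair of measured compounds differs in one place, so the size of such a change has not been seen directly in this assay here. A small step towards stronger inhibition is expected, one that may not clear the usual scatter, because compound 2 at 9400 nM shows that a measured number can be obtained. The expected step is an at least 1.4-fold lower number from compound 3 to compound 4 (0.14 log units; that floor lies within the scatter) on this estimate. For compound 4 the estimated value is 8000 nM with an expected range from 2500 nM to 20000 nM. A real chance remains that the measurement of compound 4 will give only a limit.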

Compound 4, half-maximal inhibitory concentration: >= 11300 nM
Compound 4: a limit, no number; the forecaster's own chance of this, stated with the estimate: 35%; at least 1.4-fold (0.14 log units) between middle value and limit.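

In this assay compound 4 gives >= 11300 nM, a limit of the assay and not a number. Compound 3 is likewise only a limit, so no step can be read between compound 3 and compound 4. The compounds shown leave open how far 1H-indol-3-yl in place of diethylamino changes inhibition, with most values resting at one point: the limit of >= 11300 nM in this assay, at which 3 of the 4 values shown sit.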